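The compounds below may be only part of what the source reports. "The series", "measured", "known", "first", "only" and "open" are said of these compounds alone.

Compound 1 `Oc1cccc(-c2cc(-c3ccccc3O)nc(-c3ccccc3O)c2)c1` is the only one of the three measured compounds that returns a number in an ADME assay on HEK293 cells (Homo sapiens) for cytotoxicity, read by CCK-8 assay, with a stated time of 4 days (a lower number here means a stronger inhibitor, a higher number a weaker inhibitor), where compound 1 gives 80 nM. Compound 2 `Oc1cccc(-c2cc(-c3cccc(O)c3)nc(-c3ccccc3O)c2)c1` gives > 50000 nM, which is a limit of this assay rather than a number. Compound 3 `Oc1ccc(-c2cc(-c3cccc(O)c3)cc(-c3ccccc3O)n2)cc1` likewise gives > 50000 nM, again a limit. Both of these sit at the limit of > 50000 nM in this assay, at which 2 of the 3 values shown sit.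

Compound 4 `Oc1ccc(-c2cc(-c3ccccc3O)nc(-c3ccccc3O)c2)cc1` has not yet been measured. It differs from compound 1 by 4-hydroxyphenyl in place of 3-hydroxyphenyl on an aromatic carbon; the change sits on an aromatic carbon of the shared core, meta to two 2-hydroxyphenyl groups and opposite the ring nitrogen. The measured steps that come nearest are an at least 620-fold higher number from compound 1 to compound 2 (2.79 log units; beyond the scatter) and an at least 620-fold higher number from compound 1 to compound 3 (2.79 log units; beyond the scatter), both large, yet each of them removes a 2-hydroxyphenyl group, which compound 4 keeps. The step that swaps the same pair of groups, a step that the two limits leave unreadable from compound 2 to compound 3, leaves its size unreadable. With both 2-hydroxyphenyl groups retained, compound 4 is expected to stay much closer to compound 1 than compounds 2 and 3 did, with a step of a 1.9-fold higher number from compound 1 to compound 4 (0.27 log units; within the scatter) expected. The estimate for compound 4 in this assay is 150 nM, between 30 nM and 3000 nM.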

Compound 4, half-maximal inhibitory concentration: > 50000 nM
Compound 4: only a limit was reported; the forecaster's own chance of this, stated with the estimate: 20%; at least 330-fold (2.52 log units) between middle value and limit.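

Keeping both 2-hydroxyphenyl groups is not enough to hold on to the low number: with 4-hydroxyphenyl in place of 3-hydroxyphenyl opposite the ring nitrogen as the only change, this assay shows an at least 620-fold higher number from compound 1 to compound 4 (2.79 log units; beyond the scatter). Compound 4 gives > 50000 nM, which is a limit of the assay and not a number. Compounds 1 and 4 have the same atoms, joined differently, and moving a single hydroxyl around this one ring separates them, which leaves compound 1 alone in returning a number: the limit of > 50000 nM in this assay, at which 3 of the 4 values shown sit.

Compounds 2, 3 and 4 all stand at that limit, so the steps among them cannot be read, and nothing shows how far above it any of them lies. From the compounds shown here alone, it also remains open whether this position tolerates anything other than the 3-hydroxyphenyl group while keeping a low number, for example a phenyl ring carrying an amine or a carboxylic acid in place of the hydroxyl, or a phenyl ring with no hydroxyl at all.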